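Inverting one stereocentre of compound 2

The source may hold more compounds than are shown below. What is called first, only, known or untested is meant among the compounds shown, and "the series" means these compounds.

- compound 1 `COc1cc([C@@H]2C[C@]2(CO)C(=O)Nc2ccccc2Cl)cc(OC)c1OC`: 15700 nM
- compound 2 `CCOC(=O)[C@@]1(C(=O)Nc2ccccc2)C[C@@H]1c1cc(OC)c(OC)c(OC)c1`: > 100000 nM (a limit of the assay)
- compound 3 `CCOC(=O)C1(C(=O)NCc2ccc(F)cc2)CC1c1cc(OC)c(OC)c(OC)c1`: 59400 nM; > 100000 nM (2 entries)

All values come from a functional assay on QGY cells (Homo sapiens) for cytotoxicity, read by MTT assay, with a stated time of 48 h; a lower number here means a stronger inhibitor, a higher number a weaker inhibitor.

In this assay compound 2 gives > 100000 nM, which is a limit and not a number. Compound 2 therefore has no single value, and its true position cannot be placed on the numbers shown. Among the compounds with values here, compound 3 is the only compound with several entries, and these do not give one number either: the several entries of compound 3 in this assay, 59400 nM; > 100000 nM (2 entries). The limit is common in this small set: the limit of > 100000 nM in this assay, at which 1 of the 3 values shown sits.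

The next compound is compound 4 `CCOC(=O)[C@]1(C(=O)Nc2ccccc2)C[C@@H]1c1cc(OC)c(OC)c(OC)c1`. Its relation to compound 2 is simple: the two compounds have the same atoms and bonds and differ only in configuration as drawn: 1 of 2 stereo elements differ; a stereocentre at a saturated ring carbon is drawn S in compound 2 and R in compound 4. No atom leaves or enters, and the stereocentre at a saturated ring carbon is drawn S in compound 2 and R in compound 4.

Within the data shown here, no measured pair differs only in configuration, so the size of this change has no direct precedent in this assay. Neither direction is favoured, and no shift beyond the scatter is expected. The expected change is an at least 1.1-fold lower number from compound 2 to compound 4 (0.04 log units; that floor lies within the scatter). Compound 4 is estimated at 90000 nM, with an expected range of 35000 nM to 200000 nM. A report of only a limit is considered the likelier outcome.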

Compound 4, half-maximal inhibitory concentration: 38100 nM
Beside the measured number, compound 4's estimate is 2.4-fold (0.37 log units) above it; the range from low to high includes it.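

In this assay, within the data shown here, the inversion gives an at least 2.6-fold lower number from compound 2 to compound 4 (0.41 log units; beyond the scatter), the first reading of what configuration alone does, and it lies beyond the usual scatter. No other structural difference accompanies the shift, so it belongs to the stereocentre at a saturated ring carbon: the fact that compounds 2 and 4 differ only in the configuration as drawn. Going by these compounds, compound 2 stands at > 100000 nM, which is a limit of the assay and not a number, so the step gives only a floor and its true size stays unknown.

Open, on these data alone, is what inverting the other stereocentre does, and whether this inversion gives a similar step when the ethyl ester is replaced by a carboxylic acid or a primary amide. Compound 3 gives no single number and so offers no firm reference point for the series: the several entries of compound 3 in this assay, 59400 nM; > 100000 nM (2 entries).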